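Para-fluoro on the phenyl: compounds 2 and 4

A few compounds are considered here, and "the series" means these few. Any claim that something is new, unique, unknown or untested is made for them only; others in the source may bear on it.

Compound 3 `Cc1nn2c(-c3nc4cc(Cl)c(F)cc4[nH]3)c(-c3ccccc3)nc2s1` and compound 1 `Cc1nn2c(-c3nc4cc(Cl)c(F)cc4[nH]3)c(-c3ccc(F)cc3)nc2s1` share a core; compound 2 `Cc1nn2c(-c3nc4cc(C(F)(F)F)ccc4[nH]3)c(-c3ccccc3)nc2s1` carries a different core, and the difference between the two cores is not broken down here. In a functional assay on DU-145 cells (Homo sapiens) for antiproliferative activity, read by MTT assay (a higher number here means a weaker inhibitor, a lower number a stronger inhibitor), compound 3 gives > 30000 nM, a limit of the assay. In this assay compound 1 likewise gives > 30000 nM, a limit. The change between them, (fluoro in place of hydrogen on an aromatic carbon), therefore produces a step that the two limits leave unreadable from compound 3 to compound 1, since the limit of > 30000 nM in this assay, at which 2 of the 3 values shown sit, covers both. In this assay, within the data shown here, compound 2 gives 19600 nM, the one number in the set. Compound 4 `Cc1nn2c(-c3nc4cc(C(F)(F)F)ccc4[nH]3)c(-c3ccc(F)cc3)nc2s1` is not yet measured; it differs from compound 2 by fluoro in place of hydrogen on an aromatic carbon, the same change as that from compound 3 to compound 1. With that step unreadable, the expectation for compound 4 rests on compound 2 alone at 19600 nM. The step of a 1.0-fold higher number from compound 2 to compound 4 (0.01 log units; within the scatter) is expected to stay within the usual scatter. Compound 4 is estimated at 20000 nM, between 8000 nM and 50000 nM.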

Compound 4, half-maximal inhibitory concentration: 15800 nM
Estimate against measurement, compound 4: 1.3-fold (0.10 log units) above; measured number inside the range.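

In this assay, phenyl to 4-fluorophenyl on the core of compound 2 gives a 1.2-fold lower number from compound 2 to compound 4 (0.09 log units; within the scatter), so on this core the two values cannot be told apart. Among these compounds, the same change on the other core cannot be read, since compound 3 and compound 1 both sit at a limit of the assay: the limit of > 30000 nM in this assay, at which 2 of the 4 values shown sit. Carrying the change from one core to the other is therefore untested: the one readable step describes only the core of compound 2 and does not show that the two cores respond alike.

Still open, as far as these compounds go, is whether an amine or a carboxylic acid in place of the fluoro would give a step beyond the scatter on either core. Also open, from the compounds shown here alone, is how much the difference between the two cores itself contributes.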